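Swapping Ethyl for Fluoro on the Amide Aryl Ring

The compounds below may be only part of what the source reports. "The series", "measured", "known", "first", "only" and "open" are said of these compounds alone.

Three relatives of a shared core have been tested in an ADME assay on Vero cells (Chlorocebus sabaeus) for cytotoxicity, read by resazurin assay, with a stated time of 3 days; a higher number here means a weaker inhibitor, a lower number a stronger inhibitor. Compound 1 `CN(C)c1cc2[nH]c(C3CCCCC3)nc2cc1NC(=O)c1ccc(Br)cc1` carries a 4-bromophenyl on the carbonyl carbon; in this assay compound 1 gives only the limit > 100 ug/mL. Compound 2 `CN(C)c1cc2[nH]c(C3CCCCC3)nc2cc1NC(=O)OCC(F)(F)F` puts a 2,2,2-trifluoroethoxy there, and compound 2 likewise reaches only the limit > 100 ug/mL. Compound 3 `CCc1ccc(C(=O)Nc2cc3nc(C4CCCCC4)[nH]c3cc2N(C)C)cc1`, with a 4-ethylphenyl, also stops at the limit > 100 ug/mL, so it stands alongside the other two values rather than apart from them. Because (the limit of > 100 ug/mL in this assay, at which 3 of the 3 values shown sit), the steps a step that the two limits leave unreadable from compound 1 to compound 2, a step that the two limits leave unreadable from compound 1 to compound 3 and a step that the two limits leave unreadable from compound 2 to compound 3 cannot be sized. Compound 4 `CN(C)c1cc2[nH]c(C3CCCCC3)nc2cc1NC(=O)c1ccc(F)cc1` differs from compound 3 by fluoro in place of ethyl on an aromatic carbon. Those unreadable steps are all that bear on this change, so no shift beyond the scatter is expected, and compound 4 is estimated at 100 ug/mL, between 50 ug/mL and 200 ug/mL, a step of a number no higher from compound 3 to compound 4 (the limit leaves the size open).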

Compound 4, half-maximal inhibitory concentration: > 100 ug/mL
Compound 4: no number, only a limit; the forecaster's own chance of this, stated with the estimate: 85%; the middle value lies on the limit itself.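

Compound 4 adds no step that can be sized, whether measured against compound 1, compound 2 or compound 3: the limit of > 100 ug/mL in this assay, at which 4 of the 4 values shown sit.

The compounds shown leave open whether any of these groups on the carbonyl carbon changes the reading in this assay at all.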